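Trimethoxyphenyl for methylphenyl on a pyrazolopyrimidine chalcone

This account rests on a few compounds, and the source may have more. Where it says the series, first, only, none or still open, it means among the compounds named here.

Compound 1 `COc1ccc(-c2cc(/C=C/C(=O)c3cc(OC)c(OC)c(OC)c3)nc3cc(-c4ccccc4)nn23)cc1OC`: 35000 nM
Compound 2 `COc1ccc(-c2cc(/C=C/C(=O)c3ccc(C)cc3)nc3cc(-c4ccccc4)nn23)cc1OC`: 62600 nM
Compound 3 `COc1cc(-c2cc(C(=O)/C=C/c3ccc(C)cc3)nc3cc(-c4ccccc4)nn23)cc(OC)c1OC`: 56100 nM

In an ADME assay on HEK293 cells (Homo sapiens) for antiproliferative activity, read by MTT assay, with a stated time of 24 h (a lower number here means a stronger inhibitor, a higher number a weaker inhibitor), compound 2 gives 62600 nM, and compound 1 gives 35000 nM. Their one difference is 3,4,5-trimethoxyphenyl in place of 4-methylphenyl on a carbonyl carbon, and that change made the step of a 1.8-fold lower number from compound 2 to compound 1 (0.25 log units; within the scatter). Compound 3 gives 56100 nM; the difference between its core and that of compound 2 is not broken down here.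

Compound 4 `COc1cc(/C=C/C(=O)c2cc(-c3cc(OC)c(OC)c(OC)c3)n3nc(-c4ccccc4)cc3n2)cc(OC)c1OC` is unmeasured. It differs from compound 3 by 3,4,5-trimethoxyphenyl in place of 4-methylphenyl on a double-bonded chain carbon bound to a double-bonded chain carbon. Among the measured compounds shown here, this is the same kind of change as the one from compound 2 to compound 1, but the place differs: there the group sat on a carbonyl carbon whose other neighbours are a double-bonded chain carbon, here on a double-bonded chain carbon bound to a double-bonded chain carbon. Resting on a 1.8-fold lower number from compound 2 to compound 1 (0.25 log units; within the scatter), the expected step for compound 4 is a 1.7-fold lower number from compound 3 to compound 4 (0.23 log units; within the scatter). Compound 4 is therefore estimated at 33000 nM, expected between 14000 nM and 80000 nM.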

Compound 4, half-maximal inhibitory concentration: 41000 nM
Estimate against measurement, compound 4: 1.2-fold (0.09 log units) below; the measured number falls inside the stated range.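

In this assay the swap of 4-methylphenyl for 3,4,5-trimethoxyphenyl gives a 1.4-fold lower number from compound 3 to compound 4 (0.14 log units; within the scatter) on this second core, and it can be set beside the step on the first core: the same change on two cores in this assay, a 1.8-fold lower number (0.25 log units; within the scatter) from compound 2 to compound 1 and a 1.4-fold lower number (0.14 log units; within the scatter) from compound 3 to compound 4, 1.3-fold (0.12 log units) apart, within the scatter of two such steps. The change therefore carries from one core to the other with no difference that can be told apart in this read-out. Yet each step lies within the scatter on its own, so the pairs do not show that the change moves the number at all, and two cores say nothing about a third.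

The compounds shown leave open whether a group of another kind at this place, such as an amine or a carboxylic acid, would give a step beyond the scatter.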